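The source may hold more compounds than are shown below. What is called first, only, known or untested is meant among the compounds shown, and "the series" means these compounds.

Working notes on the series, read-out an ADME assay on the whole organism (plasma, Rattus norvegicus) for protein binding, using cassette dosing, at a dose of 1 mg/kg; on this read-out higher numbers stand for a larger free fraction and lower numbers for a smaller free fraction. Compound 1 (`C[C@@H](Cn1c(=O)[nH]/c(=N\c2ccc(Oc3cncc(F)c3)cc2)n(Cc2ccc(Cl)cc2)c1=O)C(=O)O`) stands at (0.02) and compound 2 (`C[C@@H](Cn1c(=O)[nH]/c(=N\c2ccc(Oc3ccccn3)cc2)n(Cc2ccc(Cl)cc2)c1=O)C(=O)O`) stands at (0.01). These two numbers are all that is available so far, and they lie within the scatter of each other.

The next compound, compound 3 (`C[C@@H](Cn1c(=O)[nH]/c(=N\c2ccc(Oc3ccnc(F)c3)cc2)n(Cc2ccc(Cl)cc2)c1=O)C(=O)O`), keeps the rest of compound 2 and carries 2-fluoropyridin-4-yl in place of pyridin-2-yl on an oxygen on an aromatic ring.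

Among the measured compounds shown here, one measured step bears on this change: a 2.0-fold lower number from compound 1 to compound 2 (0.30 log units; within the scatter). That step exchanges 5-fluoropyridin-3-yl for pyridin-2-yl at the same place, and it stays within the scatter. For the measured compounds named here, no measurement yet covers the 2-fluoropyridin-4-yl group itself, so the evidence is thin and gives no firm direction. Both measured compounds sit close together, which points to a small move at most.

The expected change is a 1.5-fold higher number from compound 2 to compound 3 (0.18 log units; within the scatter) and is not expected to exceed the scatter. In this assay compound 3 is estimated at 0.015 with an expected range from 0.007 to 0.03 on this scale.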

Compound 3, unbound fraction: 0.013
For compound 3 the middle estimate is 1.2-fold (0.06 log units) above the measured one, and the stated range covers the measured number.
By their numbers in this assay, from the lowest: compounds 2, 3 and 1 (each within the scatter of the next).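

In this assay, 2-fluoropyridin-4-yl at this place gives a 1.3-fold higher number from compound 2 to compound 3 (0.11 log units; within the scatter) and, measured against the other fluorinated group, a 1.5-fold lower number from compound 1 to compound 3 (0.19 log units; within the scatter) in the same read-out. Among the compounds shown here, all three groups on this oxygen now lie within the scatter of one another, so the set shows no separation among the three pyridine groups, and the one new group adds no step that stands out. Compound 1 and compound 3 carry a fluorine while compound 2 does not, yet the numbers do not sort the compounds by that difference, and no measurement on hand explains this flat result or ties it to any property of the groups.

Still open is whether any group at this place can move the unbound fraction beyond the scatter, since the compounds shown offer only pyridine rings, bare or fluorinated, and a ring carrying an amine or a methoxy group would widen that test. Also open, on these data alone, is whether the same flat picture would hold once the rest of the shared core is changed, as that part stays fixed in all three compounds.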